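Chloro in place of methoxy on the far phenyl ring

A few compounds are considered here, and "the series" means these few. Any claim that something is new, unique, unknown or untested is made for them only; others in the source may bear on it.

Compound 3 `COc1cccc(-c2nc(/C=C/c3cc4ccccc4nc3OC)no2)c1` belongs to a small set of three measured compounds in an ADME assay on HepG2 cells (Homo sapiens) for cytotoxicity, read by sulforhodamine B assay, with a stated time of 48 h; on this read-out higher numbers stand for lower toxicity in this test and lower numbers for higher toxicity in this test. Its result there is a limit of the assay: compound 3 gives > 220000 nM. Compound 1 `COc1nc2ccccc2cc1/C=C/c1noc(-c2ccccc2)n1` likewise reaches only a limit, giving > 240000 nM in this assay. Compound 2 `COc1nc2ccccc2cc1/C=C/c1noc(-c2ccccc2C)n1` also stops at a limit, with > 230000 nM in this assay. All three values shown are thus limits, and compound 3 stands among them without a number of its own. The steps between the measured compounds carry the same message: a step that the two limits leave unreadable from compound 1 to compound 2, a step that the two limits leave unreadable from compound 1 to compound 3 and a step that the two limits leave unreadable from compound 2 to compound 3 are all of a size that the limits do not let one read.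

Compound 4 `COc1nc2ccccc2cc1/C=C/c1noc(-c2cccc(Cl)c2)n1` differs from compound 3 by chloro in place of methoxy on an aromatic carbon. Going by the values given here, none of the measured steps resolves a size, so no step bears on this change in a readable way, and the expectation is only that this assay will again report a limit rather than a number. For compound 4 the estimated value is 220000 nM, with a range from 100000 nM to 500000 nM. The step this estimate implies, a number no higher from compound 3 to compound 4 (the limit leaves the size open), is expected to stay within the scatter.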

Compound 4, half-maximal cytotoxic concentration: > 220000 nM
Compound 4 ended at the assay's limit; the forecaster's own chance of this, stated with the estimate: 80%; the middle value lies on the limit itself.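

In this assay compound 4 gives > 220000 nM, a limit of the assay and not a number. Going by these compounds alone, no step joining compound 4 to compound 1, compound 2 or compound 3 can be read. The compounds shown leave open whether these changes on the aromatic carbon make any difference in this assay, as none of the four has a number of its own.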